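Enlarging the Aryl Group on a Thiourea: Cytotoxicity Outlook

This account rests on a few compounds, and the source may have more. Where it says the series, first, only, none or still open, it means among the compounds named here.

Measured so far:
- compound 1, `CN(c1cc2ncc(=O)[nH]c2cc1NC(=S)NC(=O)c1ccccc1)C1CCCCC1`: 11100 nM
- compound 2, `CN(c1cc2ncc(=O)[nH]c2cc1NC(=S)NC(=O)c1ccc(F)cc1)C1CCCCC1`: 11400 nM
- compound 3, `CN(c1cc2ncc(=O)[nH]c2cc1NC(=S)Nc1ccccc1)C1CCCCC1`: 49600 nM

All three share one core and differ only in the group carried by the thiourea nitrogen. In an ADME assay on Huh-7 cells (Homo sapiens) for cytotoxicity (a lower number here means a stronger inhibitor, a higher number a weaker inhibitor), compound 3 gives the highest number of the three, the weakest inhibitor of cell growth among them. The step of a 4.5-fold higher number from compound 1 to compound 3 (0.65 log units; beyond the scatter) and the step of a 4.4-fold higher number from compound 2 to compound 3 (0.64 log units; beyond the scatter) both lie beyond the scatter, while a 1.0-fold higher number from compound 1 to compound 2 (0.01 log units; within the scatter) shows that a fluoro on the benzoyl ring changes nothing.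

Compound 4, `CN(c1cc2ncc(=O)[nH]c2cc1NC(=S)Nc1cccc2ccccc12)C1CCCCC1`, takes the next step from compound 3: naphthalen-1-yl in place of phenyl on an amide-type nitrogen. Within the data shown here, no measured pair tells how this assay answers an enlargement of the aromatic group itself; the steps seen so far concern the swap of benzoyl for phenyl and a fluoro on the ring, and neither bears directly on the present change. Among the measured compounds shown here, with no direct precedent, the expectation is a step of only modest size, if any, from compound 3 to compound 4 in this assay, leaning toward a somewhat lower number: a 1.7-fold lower number from compound 3 to compound 4 (0.22 log units; within the scatter) is the estimated step. Compound 4 is therefore expected to give about 30000 nM in this assay, with a range from 10000 nM to 80000 nM.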

Compound 4, half-maximal inhibitory concentration: 43600 nM
Estimate against measurement, compound 4: 1.5-fold (0.16 log units) below; low and high end bracket the measured number.
By their numbers in this assay, from the lowest: compounds 1 and 2 (each within the scatter of the next); then compounds 4 and 3 (each within the scatter of the next).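

In this assay, adding a second aromatic ring to the group on this amide-type nitrogen, with naphthalen-1-yl replacing phenyl, gives a 1.1-fold lower number from compound 3 to compound 4 (0.06 log units; within the scatter), so this enlargement produces no readable change. The larger aryl group also leaves the separation from the two compounds with a carbonyl-linked aryl group in place, as shown by a 3.9-fold higher number from compound 1 to compound 4 (0.59 log units; beyond the scatter) and a 3.8-fold higher number from compound 2 to compound 4 (0.58 log units; beyond the scatter). Among these four compounds, the numbers therefore fall into two groups: those with a carbonyl attached to this nitrogen and those with an aromatic ring attached directly, although no measurement here explains why the enlargement made no difference.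

The compounds shown leave open whether the same insensitivity would hold for a naphthalen-1-ylcarbonyl group, where the larger ring system is kept and the carbonyl is restored. They also do not show how this assay would respond to a non-aromatic cyclohexyl group, a longer alkyl chain, or a phenyl ring carrying an amine or a carboxylic acid at this nitrogen.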